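One Bromine Added: From Compound 2 to Compound 3

The source may report more compounds than this note shows. Statements on the series, on what has been measured and on what is new or still open speak of the compounds shown alone.

Measured so far:
compound 1, `O=C(CCCCC1CCSS1)NCc1cn(CCCOc2ccc3cc(-c4ccccc4)c(=O)oc3c2)nn1`, gives 29.8% in a functional assay on PC-12 cells (Rattus norvegicus) for cytotoxicity, read by MTT assay, with stated times of 3 h and 2 h, tested at 5 uM; a lower number here means a weaker effect, a higher number a stronger effect of the compound at the concentration tested;
compound 2, `O=C(CCCCC1CCSS1)NCc1cn(CCCCOc2ccc3cc(-c4ccccc4)c(=O)oc3c2)nn1`, gives 32.8% in this assay.

Of the two numbers shown, that of compound 2 is the higher, yet compound 1 lies within the usual scatter of it, so no difference between them can be claimed. Compound 3, `O=C(CCCCC1CCSS1)NCc1cn(CCCCOc2ccc3cc(-c4ccc(Br)cc4)c(=O)oc3c2)nn1`, differs from compound 2 by bromo in place of hydrogen on an aromatic carbon. Within the data shown here, no step of this kind has been measured here. In this assay a step of a number 2.2 percentage points higher from compound 2 to compound 3 (within the scatter) is expected, upward if at all and not beyond the scatter. Compound 3 is therefore estimated at 35%, between 20% and 50%.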

Compound 3, a percentage reported as activity, at one concentration (the size of the read-out at that concentration, not a potency): 40.5%
Beside the measured number, compound 3's estimate is 5.5 percentage points below it; the measured number falls inside the stated range.
By their numbers in this assay, from the lowest: compounds 1, 2 and 3 (each within the scatter of the next, the first and the last beyond it).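

In this assay, among these compounds, the change from phenyl to 4-bromophenyl amounts to a number 7.7 percentage points higher from compound 2 to compound 3 (within the scatter) and is the first step here between compounds that differ in one place. It shows that this aromatic carbon, para to a large group, carries a bromo without a shift beyond the scatter. Nothing available accounts for the size of this step. Going by these compounds, whether an amine, a carboxylic acid or a methoxy group at this carbon would move the read-out beyond the scatter stays open. So does whether chlorine or fluorine would behave as bromine does here.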